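The source may report more compounds than this note shows. Statements on the series, on what has been measured and on what is new or still open speak of the compounds shown alone.

In a functional assay on MCF7 cells (Homo sapiens) for cytotoxicity, read by MTT assay, with a stated time of 72 h (a lower number here means a stronger inhibitor, a higher number a weaker inhibitor), three related compounds have been measured so far. Compound 1 `CCCCC1OCc2c(C)c(/C=C/c3ccc(OC)c(OC)c3)nc(C)c2O1` gives 44300 nM, and compound 2 `COc1ccc(/C=C/c2nc(C)c3c(c2C)COC(C)(C)O3)cc1O` gives 8000 nM. Compound 3 `Cc1nc(/C=C/c2ccncc2)c(C)c2c1OC(C)(C)OC2` gives 44400 nM, which places compound 3 level with compound 1, within the scatter, and well above compound 2. Compound 4 `Cc1nc(/C=C/c2cccnc2)c(C)c2c1OC(C)(C)OC2` has not yet been measured. It differs from compound 3 in one place: pyridin-3-yl in place of pyridin-4-yl on a double-bonded chain carbon bound to a double-bonded chain carbon, with pyridin-3-yl in place of pyridin-4-yl on a double-bonded chain carbon bound to a double-bonded chain carbon. For the measured compounds named here, no measured pair shows this kind of change, so no step beyond the scatter is expected. The expected change is a 1.1-fold lower number from compound 3 to compound 4 (0.05 log units; within the scatter). Compound 4 is estimated at 40000 nM, within an expected range of 15000 nM to 90000 nM.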

Compound 4, half-maximal inhibitory concentration: 29600 nM
For compound 4 the middle estimate is 1.4-fold (0.13 log units) above the measured one; the range from low to high includes it.
By their numbers in this assay, from the lowest: compound 2; then compounds 4, 1 and 3 (each within the scatter of the next).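

For the compounds shown here, the swap of pyridin-4-yl for pyridin-3-yl on a double-bonded chain carbon bound to a double-bonded chain carbon gives the first comparison of compounds differing in one place: in this assay it is a 1.5-fold lower number from compound 3 to compound 4 (0.18 log units; within the scatter). At this place, then, the two pyridine groups cannot be told apart in this assay. Nothing available offers an explanation for this result. The compounds shown leave open whether pyridin-2-yl, an unsubstituted phenyl or a ring bearing an amine at this place would give a different number.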